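Aryl swap on the ring amine of a thiophene series

A few compounds are considered here, and "the series" means these few. Any claim that something is new, unique, unknown or untested is made for them only; others in the source may bear on it.

In an assay on CHO cells for displacement of a labelled ligand from adenosine receptor A1 (Homo sapiens) (on this read-out higher numbers stand for weaker binding and lower numbers for tighter binding), compound 1 `Nc1scc(CN2CCN(C3CCCCC3)CC2)c1C(=O)c1ccc(Cl)cc1` gives 1.9 nM and compound 2 `N#Cc1ccc(N2CCN(Cc3csc(N)c3C(=O)c3ccc(Cl)cc3)CC2)cc1` gives 1.8 nM; the two numbers lie within the scatter of each other, so neither compound can be placed ahead of the other on this read-out, and compound 2 merely shows the lower of the two figures. Compound 3 `Nc1scc(CN2CCN(c3ccccn3)CC2)c1C(=O)c1ccc(Cl)cc1` is not yet measured; it differs from compound 2 in one place: pyridin-2-yl in place of 4-cyanophenyl on an amine nitrogen in a ring. Within the data shown here, the only measured step at this position is a 1.1-fold lower number from compound 1 to compound 2 (0.02 log units; within the scatter), where a saturated ring gave way to an aryl group with no change beyond the scatter. Among the measured compounds shown here, that single step suggests the amine substituent is tolerant to exchange, though only two compounds support this. The step from compound 2 to compound 3 is therefore expected to be small, a 1.6-fold higher number from compound 2 to compound 3 (0.19 log units; within the scatter), with slightly more room for loss than for gain. Compound 3 is estimated at 2.8 nM, within a range of 1 nM to 8 nM.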

Compound 3, dissociation constant: 1.7 nM
Estimate against measurement, compound 3: 1.6-fold (0.22 log units) above, within the range that was stated.
By their numbers in this assay, from the lowest: compounds 3, 2 and 1 (each within the scatter of the next).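

In this assay the exchange of 4-cyanophenyl for pyridin-2-yl removes the nitrile and puts a hetero atom into the aromatic ring, yet it gives a 1.1-fold lower number from compound 2 to compound 3 (0.02 log units; within the scatter) and so shows that the nitrile is not required for binding in these compounds. Set against the saturated cyclohexyl group, pyridin-2-yl gives a 1.1-fold lower number from compound 1 to compound 3 (0.05 log units; within the scatter) and all three groups on this amine nitrogen now lie within the scatter of each other, a flat picture that holds for these compounds alone. Nothing available explains this flatness.

The compounds shown leave open whether that tolerance extends to a carboxylic acid, a primary amine or a longer alkyl chain on the same nitrogen. They also leave open whether a second ring nitrogen, as in pyrimidin-2-yl, would keep the number within the scatter.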